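Aryl for carbamoylmethyl on the ring nitrogen: compound 4

The compounds below may be only part of what the source reports. "The series", "measured", "known", "first", "only" and "open" are said of these compounds alone.

Three compounds share one core. Compound 1 `CCOC(=O)C1=Cc2ccccc2OC1(OCc1cn(CC(=O)Nc2cccc(Cl)c2)nn1)C(F)(F)F` gives 11600 nM in a functional assay on MCF7 cells (Homo sapiens) for inhibition, read by MTT assay, with a stated time of 24 h; a lower number here means a stronger inhibitor, a higher number a weaker inhibitor. Compound 2 `CCOC(=O)C1=Cc2ccccc2OC1(OCc1cn(-c2ccc(F)c([N+](=O)[O-])c2)nn1)C(F)(F)F` gives 16200 nM in this assay, and compound 3 `CCOC(=O)C1=Cc2ccccc2OC1(OCc1cn(CC(=O)Nc2ccccc2F)nn1)C(F)(F)F` gives 42100 nM. Compound 3 stands highest of the three numbers, with compound 2 nearest and compound 1 furthest. Compound 4 `CCOC(=O)C1=Cc2ccccc2OC1(OCc1cn(-c2ccc(F)c(Cl)c2)nn1)C(F)(F)F` differs from compound 3 in one place: 3-chloro-4-fluorophenyl in place of ((2-fluorophenyl)carbamoyl)methyl on an aromatic nitrogen.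

Among the compounds with values here, two measured steps bear on this change. a 2.6-fold higher number from compound 2 to compound 3 (0.41 log units; beyond the scatter) is the nearest precedent, as it exchanges a directly attached aryl on the ring nitrogen for a carbamoylmethyl group; compound 4 reverses that exchange. a 1.4-fold higher number from compound 1 to compound 2 (0.15 log units; within the scatter) shows that a directly attached aryl and a carbamoylmethyl group can also sit within the scatter of one another. a 3.6-fold higher number from compound 1 to compound 3 (0.56 log units; beyond the scatter) concerns only the aryl on the amide nitrogen, which compound 4 lacks. A return toward the level of compound 2 is therefore expected. The estimated step is a 2.8-fold lower number from compound 3 to compound 4 (0.45 log units; beyond the scatter), toward a lower number. The estimate for compound 4 in this assay is 15000 nM, with a range from 7000 nM to 35000 nM.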

Compound 4, half-maximal inhibitory concentration: 25300 nM
Estimate against measurement, compound 4: 1.7-fold (0.23 log units) below; measured number inside the range.
By their numbers in this assay, from the lowest: compounds 1, 2, 4 and 3 (each within the scatter of the next, the first and the last beyond it).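

In this assay the 3-chloro-4-fluorophenyl in place of ((2-fluorophenyl)carbamoyl)methyl on the aromatic nitrogen gives (a 1.7-fold lower number from compound 3 to compound 4 (0.22 log units; within the scatter)), so this exchange does not clear the scatter, whereas the exchange with the nitro-bearing aryl does (a 2.6-fold higher number from compound 2 to compound 3 (0.41 log units; beyond the scatter)). Chloro in place of nitro gives the first reading of a change on the directly attached aryl itself (a 1.6-fold higher number from compound 2 to compound 4 (0.19 log units; within the scatter)), and that step also stays within the scatter. Set against ((3-chlorophenyl)carbamoyl)methyl, the same aryl gives a modest step beyond the scatter (a 2.2-fold higher number from compound 1 to compound 4 (0.34 log units; beyond the scatter)), so in these compounds the size of the exchange depends on which carbamoylmethyl group leaves.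

From the compounds shown here alone, an amine or a carboxylic acid on the directly attached phenyl, or a longer chain in place of carbamoylmethyl, remains open. No measurement shown accounts for any of these steps.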